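The compounds below may be only part of what the source reports. "The series", "measured", "known", "first", "only" and "open" are said of these compounds alone.

Compound 1 `CC(C)=CC(=O)Nc1cccc(Oc2nc(Nc3cccc(C#N)c3)nc3c2CSCC3)c1` gives 29200 nM in a functional assay on HeLa cells (Homo sapiens) for antiproliferative activity, read by MTT assay, with a stated time of 72 h; on this read-out lower numbers stand for stronger inhibition and higher numbers for weaker inhibition. Compound 2 `CC(C)/C=C/C(=O)Nc1cccc(Oc2nc(Nc3cccc(C#N)c3)nc3c2CSCC3)c1` differs from it only in the acyl side chain: 3-methylbut-1-en-1-yl in place of 2-methylprop-1-en-1-yl on a carbonyl carbon. In this assay compound 2 gives 22800 nM, a step of a 1.3-fold lower number from compound 1 to compound 2 (0.11 log units; within the scatter). Compound 3 `COc1ccc(Nc2nc3c(c(Oc4cccc(NC(=O)C=C(C)C)c4)n2)CSCC3)cn1` shares the acyl side chain of compound 1 but has a different core, the two cores differing as follows: 6-methoxypyridin-3-yl in place of 3-cyanophenyl on a nitrogen on an aromatic ring. In this assay compound 3 gives 29200 nM, and the step is no change at the digits printed from compound 1 to compound 3 (within the scatter). Compound 4 `COc1ccc(Nc2nc3c(c(Oc4cccc(NC(=O)/C=C/C(C)C)c4)n2)CSCC3)cn1` is now built from compound 3 by the same change that led from compound 1 to compound 2: 3-methylbut-1-en-1-yl in place of 2-methylprop-1-en-1-yl on a carbonyl carbon. The place of the change, on a carbonyl carbon whose other neighbour is an amide-type nitrogen, is the same in both pairs, so the change is the same. Because that change gave a 1.3-fold lower number from compound 1 to compound 2 (0.11 log units; within the scatter), a step of similar size, a 1.3-fold lower number from compound 3 to compound 4 (0.10 log units; within the scatter), is expected here. On that basis compound 4 is estimated to give 23000 nM in this assay, with a likely range from 12000 nM to 45000 nM.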

Compound 4, half-maximal inhibitory concentration: 27800 nM
Compound 4: middle estimate off by 1.2-fold (0.08 log units), on the low side; measured number inside the range.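

In this assay, among the compounds shown here, 3-methylbut-1-en-1-yl in place of 2-methylprop-1-en-1-yl on a carbonyl carbon now gives a 1.1-fold lower number from compound 3 to compound 4 (0.02 log units; within the scatter), and this agrees with the same change on the core of compound 1: the same change on two cores in this assay, a 1.3-fold lower number (0.11 log units; within the scatter) from compound 1 to compound 2 and a 1.1-fold lower number (0.02 log units; within the scatter) from compound 3 to compound 4, 1.2-fold (0.09 log units) apart, within the scatter of two such steps Read the other way round, 6-methoxypyridin-3-yl in place of 3-cyanophenyl on a nitrogen on an aromatic ring gives a 1.2-fold higher number from compound 2 to compound 4 (0.09 log units; within the scatter), and this also agrees with its earlier step: the same change on two cores in this assay, no change at the digits printed (within the scatter) from compound 1 to compound 3 and a 1.2-fold higher number (0.09 log units; within the scatter) from compound 2 to compound 4, 1.2-fold (0.09 log units) apart, within the scatter of two such steps Every one of these steps lies within the scatter, so the agreement shows only that neither change shifted the number measurably on either core, not that a real effect of the side chain carries from one core to the other.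

The compounds shown leave open whether a different side chain on the carbonyl carbon, such as a longer chain or a chain ending in an amine or a carboxylic acid, would give a step beyond the scatter in this assay. They also leave open whether such a step would keep its size when carried to the other core.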